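The source may report more compounds than this note shows. Statements on the series, on what has been measured and on what is new or still open speak of the compounds shown alone.

Working notes on the series. In an assay on isolated protein for inhibition of Fatty-acid amide hydrolase 1 (Homo sapiens) (a higher number here means a weaker inhibitor, a lower number a stronger inhibitor), compound 1, `CCCCCCCC/C=C\CCCCCCC(=O)c1nnn(C)n1`, gives 65 nM, the lowest of the three numbers in hand. Compound 3, `CCCCCCCC/C=C\CCCCCCC(=O)c1ncc(-c2ccccc2)o1`, gives 320 nM in this assay, and compound 2, `CCCCCCCCCCCCCC(=O)C(F)(F)F`, gives 490 nM in this assay; both of these numbers stand clearly above that of compound 1, and no single-point comparison joins any two of the three structures, so nothing more is read from them than the ordering of the values.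

Compound 4, `CCCCCCCC/C=C\CCCCCCC(=O)c1cccnn1`, has not yet been measured. It differs from compound 1 in one place: pyridazin-3-yl in place of 2-methyl-2H-tetrazol-5-yl on a carbonyl carbon. For the measured compounds named here, no measured pair in the set isolates this kind of change, so the expectation rests on the standing of compound 1 alone. A step from compound 1 to compound 4 of a 2.6-fold lower number from compound 1 to compound 4 (0.41 log units; beyond the scatter) is expected in this assay, towards a lower number but of a size that may not clear the scatter. On that basis compound 4 is estimated to give 25 nM in this assay, within a range of 5 nM to 120 nM.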

Compound 4, inhibition constant: 130 nM
For compound 4 the middle estimate is 5.2-fold (0.72 log units) below the measured one; measured number above the stated range.
By their numbers in this assay, from the lowest: compounds 1 and 4 (each within the scatter of the next); then compounds 3 and 2 (each within the scatter of the next).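

For the compounds shown here, with pyridazin-3-yl in place of 2-methyl-2H-tetrazol-5-yl on a carbonyl carbon, the series gains its only single-place comparison, and it reads a 2.0-fold higher number from compound 1 to compound 4 (0.30 log units; within the scatter) in this assay. At this position, then, a six-membered aromatic ring with 2 hetero atoms and a five-membered aromatic ring with 4 hetero atoms cannot be told apart in this assay, despite the different ring size and hetero atom count. No available evidence bears on why the two groups read alike here.

Still open, from the compounds shown here alone, is whether a pyridin-2-yl ring or an open-chain amide on the same carbonyl carbon would stay within the scatter of these two compounds. Also open, going by these compounds, is whether a nitrile or a carboxylic acid on the pyridazin-3-yl ring, or a shorter chain on the carbonyl carbon, would shift the number beyond it.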